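Working notes on a short biaryl growth-inhibition series

The source may report more compounds than this note shows. Statements on the series, on what has been measured and on what is new or still open speak of the compounds shown alone.

Measured compounds:
compound 1 `Cc1ccc2[nH]c(-c3ccc(-c4ccc(-c5cccc(Cl)c5)cc4)cc3)nc2c1` gives 2120 nM
compound 2 `COc1ccc(-c2ccc(-c3ccc(-c4nc5cc(C)ccc5[nH]4)cc3)cc2)cc1OC` gives 1310 nM
compound 3 `Oc1cccc2[nH]c(-c3ccc(-c4ccc(-c5cccc(Cl)c5)cc4)cc3)nc12` gives 2310 nM

All three were read in a functional assay on Gurav cells (Homo sapiens) for inhibition, read by sulforhodamine B assay; on this read-out higher numbers stand for weaker inhibition of growth and lower numbers for stronger inhibition of growth. Compound 2 differs from compound 1 in one place: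
3,4-dimethoxyphenyl in place of 3-chlorophenyl on an aromatic carbon
This change gave a 1.6-fold lower number from compound 1 to compound 2 (0.21 log units; within the scatter). The difference between the core of compound 1 and the core of compound 3 is not broken down here; their two values lie within the scatter of each other.

Compound 4 `COc1ccc(-c2ccc(-c3ccc(-c4nc5c(O)cccc5[nH]4)cc3)cc2)cc1OC` is not yet measured in this assay. It carries the same change relative to compound 3:
3,4-dimethoxyphenyl in place of 3-chlorophenyl on an aromatic carbon
The step from compound 3 to compound 4 is estimated as a 1.6-fold lower number from compound 3 to compound 4 (0.20 log units; within the scatter). This rests on the earlier pair, because a 1.6-fold lower number from compound 1 to compound 2 (0.21 log units; within the scatter) was within the scatter, so only a small shift is expected. Compound 4 is expected to give about 1450 nM, with a likely range from 700 nM to 3000 nM.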

Compound 4, concentration for 50% growth inhibition: 1110 nM
Compound 4: middle estimate off by 1.3-fold (0.12 log units), on the high side, and the stated range covers the measured number.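

In this assay, the exchange of 3-chlorophenyl for 3,4-dimethoxyphenyl gives steps of matching size on the two cores: the same change on two cores in this assay, a 1.6-fold lower number (0.21 log units; within the scatter) from compound 1 to compound 2 and a 2.1-fold lower number (0.32 log units; beyond the scatter) from compound 3 to compound 4, 1.3-fold (0.11 log units) apart, within the scatter of two such steps. The new step, a 2.1-fold lower number from compound 3 to compound 4 (0.32 log units; beyond the scatter), is modest, and agreement on two cores does not show that the change would carry to any further core. With 3,4-dimethoxyphenyl kept, the exchange of 5-methyl-1H-benzimidazol-2-yl for 4-hydroxy-1H-benzimidazol-2-yl gives a 1.2-fold lower number from compound 2 to compound 4 (0.07 log units; within the scatter).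

As far as these compounds go, it remains open whether a terminal ring carrying an amine or a carboxylic acid would give a step of similar size. Also open is which of the two methoxy groups, if either, accounts for the step.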